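One Methyl, Two Cores: Expected Growth Inhibition for Compound 4

A few compounds are considered here, and "the series" means these few. Any claim that something is new, unique, unknown or untested is made for them only; others in the source may bear on it.

Three compounds have been measured in a functional assay on HeLa cells (Homo sapiens) for cytotoxicity, read by MTT assay, with a stated time of 72 h, tested at 10 uM; on this read-out lower numbers stand for less inhibition of growth and higher numbers for more inhibition of growth at the one concentration tested:
compound 1 `N/C(=N\NC(=S)N1CCCCCC1)c1ccccn1` gives 67.4%
compound 2 `N/C(=N\NC(=S)N1CCOCC1)c1ccccn1` gives 56.3%
compound 3 `Cc1cccc(/C(N)=N/NC(=S)N2CCOCC2)n1` gives 85.4%

Compound 1 and compound 2 differ in their cores, and that difference is not broken down here; the values alone show compound 1 standing above compound 2 in this assay. Compound 3 arises from compound 2 by methyl in place of hydrogen on an aromatic carbon and moves by a number 29.1 percentage points higher from compound 2 to compound 3 (beyond the scatter). Compound 4 `Cc1cccc(/C(N)=N/NC(=S)N2CCCCCC2)n1` arises from compound 1 by methyl in place of hydrogen on an aromatic carbon, the same change at the same place. This single step has been seen only once, and only on the core of compound 2, so compound 4 carries it onto a second core. Compound 1 already stands at 67.4%, leaving less room upward. Compound 4 is therefore expected to move by a number 19.6 percentage points higher from compound 1 to compound 4 (beyond the scatter) in this assay. Compound 4 is estimated at 87%, between 72% and 97%.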

Compound 4, percent growth inhibition at one concentration: 71.7%
Estimate against measurement, compound 4: 15.3 percentage points above; the whole stated range lies above it.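

In this assay methyl in place of hydrogen on an aromatic carbon gives a number 4.3 percentage points higher from compound 1 to compound 4 (within the scatter) and so adds nothing that can be told from the scatter on this second core. The change does not carry over at the same size from one core to the other: the same change on two cores in this assay, a number 29.1 percentage points higher (beyond the scatter) from compound 2 to compound 3 and a number 4.3 percentage points higher (within the scatter) from compound 1 to compound 4, 24.8 percentage points apart, beyond the scatter of two such steps. The size of the step seen on one core therefore cannot simply be transferred to the other, but this does not show what in the cores sets them apart, and two pairs give no rule for any further core.

On these data alone, whether an ethyl, a methoxy or an amine at this place would follow either step stays open. So does the outcome of the methyl on any other core.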